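A few compounds are considered here, and "the series" means these few. Any claim that something is new, unique, unknown or untested is made for them only; others in the source may bear on it.

Compound 2 `CCCCC[Se]c1nc(NCc2ccccc2)c2ccccc2n1` carries a benzyl group on a ring nitrogen of the shared core, where compound 1 `CCCCC[Se]c1nc(N)c2ccccc2n1` carries hydrogen. In a functional assay on HT-29 cells (Homo sapiens) for cytotoxicity, read by MTT assay, with a stated time of 72 h (on this read-out higher numbers stand for weaker inhibition of growth and lower numbers for stronger inhibition of growth), compound 1 gives > 100000 nM, which is a limit of the assay and not a measured number. In this assay compound 2 gives > 100000 nM, again a limit rather than a number. Because both values sit at the limit of > 100000 nM in this assay, at which 2 of the 2 values shown sit, the step that the two limits leave unreadable from compound 1 to compound 2 cannot be read, and compound 2 stands only at that limit, with no measured number of its own. Compound 3 `CSc1nc(NCc2ccccc2)c2ccccc2n1` differs from compound 2 in one place: a group of 2 heavy atoms (1 carbon, 1 sulfur; no ring) in place of a group of 6 heavy atoms (5 carbon, 1 selenium; no ring), on an aromatic carbon. For the measured compounds named here, no measured step touches that position, so there is nothing to show how such an exchange moves the read-out. Going by the values given here, the only guide is the limit seen for compound 2, and compound 3 is expected to stay near it. The step of a number no higher from compound 2 to compound 3 (the limit leaves the size open) is therefore expected to lie within the scatter. Compound 3 is estimated at 100000 nM, with a range from 30000 nM to 300000 nM, and most likely reported again only as a limit.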

Compound 3, concentration for total growth inhibition: > 100000 nM
Compound 3 ended at the assay's limit (the forecaster's own chance of this, stated with the estimate: 75%); the middle value sits exactly at the limit.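

In this assay compound 3 gives > 100000 nM, a limit of the assay and not a number. The step from compound 2 to compound 3 therefore cannot be read: the limit of > 100000 nM in this assay, at which 3 of the 3 values shown sit.

The compounds shown leave open how strongly compound 1, compound 2 or compound 3 inhibits growth, and whether swapping the group on the aromatic carbon changes that at all.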